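The source may report more compounds than this note shows. Statements on the series, on what has been measured and on what is new or still open speak of the compounds shown alone.

Working notes on the series. Among the compounds with values here, of the two numbers so far measured in an ADME assay on HEL cells (Homo sapiens) for cytotoxicity (a higher number here means that more compound is tolerated, a lower number that less compound is tolerated), compound 2 `O=C(COc1cccc2ccccc12)N/N=C/c1cccc([N+](=O)[O-])c1` gives the lower one, 61.2 ug/mL. The nearest number belongs to compound 1 `O=C(COc1cccc2ccccc12)N/N=C/c1ccc(Br)cc1`, which in this assay gives 100 ug/mL; the gap between the two is within the usual scatter of repeated measurements, so no real difference between compound 1 and compound 2 can be claimed. Compound 3 `O=C(COc1cccc2ccccc12)N/N=C/c1cccc(Br)c1` has not yet been measured in this assay. Compound 3 differs from compound 2 by bromo in place of nitro on an aromatic carbon. Within the data shown here, no step between two measured compounds covers this change, so its size cannot be read from the series. Compound 3 is expected to come out near 80 ug/mL, with a range from 40 ug/mL to 160 ug/mL. The expected step of a 1.3-fold higher number from compound 2 to compound 3 (0.12 log units; within the scatter) is small and, if anything, upward, hardly beyond the scatter, because compound 1, which also carries bromo, gives 100 ug/mL in this assay.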

Compound 3, half-maximal cytotoxic concentration: 48.6 ug/mL
For compound 3 the middle estimate is 1.6-fold (0.22 log units) above the measured one; measured number inside the range.
By their numbers in this assay, from the lowest: compounds 3, 2 and 1 (each within the scatter of the next, the first and the last beyond it).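

In this assay the exchange at this aromatic carbon, meta to a large group, gives a 1.3-fold lower number from compound 2 to compound 3 (0.10 log units; within the scatter) and so cannot be told apart from no change: with bromo in place of nitro, compound 2 and compound 3 read alike. Within the data shown here, the place of the bromo does show up, since 3-bromophenyl in place of 4-bromophenyl gives a 2.1-fold lower number from compound 1 to compound 3 (0.31 log units; beyond the scatter) as the first step beyond the scatter, though only a modest one. Nothing at hand explains why the number follows the place of the bromo.

Open, on these data alone, is whether the number also follows the place of the group when that group is nitro rather than bromo. Also open, as far as these compounds go, is how an amine, a carboxylic acid or a longer chain on this aromatic carbon would read in this assay and whether any of them would step beyond the scatter from compound 2.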